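The source may report more compounds than this note shows. Statements on the series, on what has been measured and on what is new or still open speak of the compounds shown alone.

The series shares one core, varied only in the five-membered ring that sits on an aromatic carbon of the fused six-membered ring. Compound 1 `c1cc(-c2cn[nH]c2)c2c(c1)C(c1ncc[nH]1)CC2` carries 1H-pyrazol-4-yl there. In a functional assay on CHO cells for agonist activity at Alpha-1B adrenergic receptor (Homo sapiens), read by FLIPR and calcium flux (a higher number here means that more compound is needed for the effect, a lower number that less compound is needed), compound 1 reaches only the limit > 10000 nM. Compound 2 `Cn1ccc(-c2cccc3c2CCC3c2ncc[nH]2)n1` carries 1-methyl-1H-pyrazol-3-yl. In this assay compound 2 also sits at the limit > 10000 nM. Going by the values given here, compound 3 `c1cc(-c2ccn[nH]2)c2c(c1)C(c1ncc[nH]1)CC2` carries 1H-pyrazol-5-yl, and in this assay compound 3 gives 600 nM, the only number in the set; the other two values stand at the limit of > 10000 nM in this assay, at which 2 of the 3 values shown sit. The steps of an at least 16-fold lower number from compound 1 to compound 3 (1.22 log units; beyond the scatter) and an at least 16-fold lower number from compound 2 to compound 3 (1.22 log units; beyond the scatter) are both large and both lead to compound 3, so the 1H-pyrazol-5-yl ring stands apart from the other two rings tried.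

Compound 4 `c1cc(-c2ncco2)c2c(c1)C(c1ncc[nH]1)CC2` moves away from that ring: 1,3-oxazol-2-yl in place of 1H-pyrazol-5-yl on an aromatic carbon. Among the compounds with values here, no measured pair carries this exact change, but each earlier exchange of the ring at this position shifted the result by a large amount, and every ring other than 1H-pyrazol-5-yl so far has ended at the limit. The step of an 8.3-fold higher number from compound 3 to compound 4 (0.92 log units; beyond the scatter) is therefore expected to be a clear loss in this assay, with a fair chance that only a limit is reported. Compound 4 is estimated at 5000 nM, within 1500 nM to 20000 nM.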

Compound 4, half-maximal effective concentration: > 10000 nM
Compound 4: only a limit was reported; the forecaster's own chance of this, stated with the estimate: 45%; at least 2.0-fold (0.30 log units) between middle value and limit.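

The exchange of 1H-pyrazol-5-yl for 1,3-oxazol-2-yl gives an at least 16-fold higher number from compound 3 to compound 4 (1.22 log units; beyond the scatter), so a second five-membered aromatic ring with the same count of heavy atoms does not keep what compound 3 shows. The change replaces a nitrogen with an oxygen and takes the hydrogen-bond donors from 1 to 0 and the acceptors from 1 to 2, but this pair alone does not tie the loss to either count. In this assay compound 3 remains the only compound with a number rather than a limit, the other three sitting at one value: the limit of > 10000 nM in this assay, at which 3 of the 4 values shown sit.

The steps from compound 1 and from compound 2 to compound 4 cannot be read, both ends of each being limits, so the order among these three compounds stays open. Also open, on these data alone, is whether another ring on this aromatic carbon, such as 1H-imidazol-2-yl or 1,2,4-triazol-3-yl, or a 1H-pyrazol-5-yl ring carrying a methyl group or an amine, would give a lower number than compound 3 or fall back to the limit.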